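The compounds below may be only part of what the source reports. "The series", "measured", "known", "first", "only" and "open" are said of these compounds alone.

Three measured compounds share one core. Compound 1 `c1ccc2oc(-c3cn4nc(C5CC5)sc4n3)cc2c1`, compound 2 `COc1cc(OCc2cccc(CCc3ccccc3)c2)c2cc(-c3cn4nc(OC)sc4n3)oc2c1` and compound 3 `COc1nn2cc(-c3cc4ccc(OCc5ccccc5)cc4o3)nc2s1` were each tested in an ADME assay on microsomes from liver (Rattus norvegicus) for metabolic stability, with a stated time of 10 min; on this read-out lower numbers stand for a less stable compound and higher numbers for a more stable compound. In this assay compound 1 gives 53%. In this assay compound 2 gives 68%, while compound 3 gives 68%. Compound 2 and compound 3 stand level at the digits shown, and together they hold the upper end of the three numbers; the gap from compound 2 down to compound 1 lies beyond the scatter, so compound 1 is the compound furthest from compound 2.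

Compound 4 `COc1cc(OCc2cccc(Oc3ccccc3)c2)c2cc(-c3cn4nc(OC)sc4n3)oc2c1` has not yet been measured in this assay. It differs from compound 2 in one place: phenoxy in place of phenethyl on an aromatic carbon.

Among the measured compounds shown here, no step between two measured compounds of this kind is available, so the expectation rests on compound 2 alone. The step of a number 3 percentage points lower from compound 2 to compound 4 (within the scatter) is expected to be small, with no clear direction and no move beyond the scatter. Compound 4 is therefore estimated at 65%, with a range from 48% to 82%.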

Compound 4, percent of the compound remaining: 42%
Beside the measured number, compound 4's estimate is 23 percentage points above it; the measured number lies below the stated range.
By their numbers in this assay, from the lowest: compound 4; then compound 1; then compounds 2 and 3 (each within the scatter of the next).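

In this assay the exchange of phenethyl for phenoxy, on an aromatic carbon meta to a large group, gives a number 26 percentage points lower from compound 2 to compound 4 (beyond the scatter) and so shows that the read-out at this position is sensitive to the group placed there. The two groups are close in what can be counted: each holds one six-membered aromatic ring of carbon only, and the change adds one hydrogen-bond acceptor, so even a small exchange at this place can matter. Nothing measured here explains the change.

As far as these compounds go, whether a benzyl or a phenylamino group at this aromatic carbon would stand nearer compound 2 or nearer compound 4 remains open. From the compounds shown here alone, it is also open whether the same exchange would give a similar step with another group on the shared core.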